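This account rests on a few compounds, and the source may have more. Where it says the series, first, only, none or still open, it means among the compounds named here.

Of the compounds shown here, three have been tested so far in a functional assay on A2780 cells (Homo sapiens) for cytotoxicity, read by sulforhodamine B assay, with a stated time of 72 h; a lower number here means a stronger inhibitor, a higher number a weaker inhibitor. Compound 1 `O=C(NCc1ccc(S(=O)(=O)c2ccccc2)cc1)N1Cc2cccnc2C1` reads > 2000 nM, which is a limit and not a number. Compound 2 `O=C(NCc1ccc(S(=O)(=O)c2ccccc2)cc1)N1CCc2ccncc2C1` reads > 2000 nM, again a limit. For the measured compounds named here, compound 3 `O=C(NCc1ccc(S(=O)(=O)c2cc(F)cc(F)c2)cc1)N1Cc2ccncc2C1` gives 6.3 nM, the only true number among the three, and this makes it the natural reference point for what comes next.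

Compound 4 `O=C(NCc1ccc(S(=O)(=O)C2CCCOC2)cc1)N1Cc2ccncc2C1` has not yet been measured. It keeps the rest of compound 3 and changes one group: oxan-3-yl in place of 3,5-difluorophenyl on a sulfonyl sulfur. Put simply, oxan-3-yl stands in place of 3,5-difluorophenyl on a sulfonyl sulfur. Going by the values given here, no two measured compounds differ in one place only, so the data offer no direct guide to this swap, and any forecast stays loose. With compound 3 at 6.3 nM as the only anchor, a moderate weakening in this assay is expected rather than a complete loss of activity. The estimated change is a 4.8-fold higher number from compound 3 to compound 4 (0.68 log units; beyond the scatter). For compound 4 the expected value is 30 nM, with an estimated range of 6 nM to 200 nM.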

Compound 4, half-maximal inhibitory concentration: 32 nM
Compound 4: the middle estimate sits 1.1-fold (0.03 log units) below what was measured; the range from low to high includes it.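

The swap of oxan-3-yl in place of 3,5-difluorophenyl on the sulfonyl sulfur gives a 5.1-fold higher number from compound 3 to compound 4 (0.71 log units; beyond the scatter) in this assay. This shows that a ring of carbon only with aromatic character is not required at this place, since a non-aromatic ring carrying an oxygen still gives a true number, although the swap is not neutral. Compound 1 and compound 2 could not show this, as each gives a limit and not a number: the limit of > 2000 nM in this assay, at which 2 of the 4 values shown sit.

This single step removes the fluorines and the aromatic ring and adds the ring oxygen all at once, so it does not separate their contributions. Going by these compounds, how a cyclohexyl ring, which has no oxygen, or a piperidine ring, which holds an amine, would read at this place stays open.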